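A few compounds are considered here, and "the series" means these few. Any claim that something is new, unique, unknown or untested is made for them only; others in the source may bear on it.

Of the compounds shown here, three built on one shared core have been tested in a functional assay on A-431 cells (Homo sapiens) for antiproliferative activity, read by MTT assay, with a stated time of 72 h; a lower number here means a stronger inhibitor, a higher number a weaker inhibitor. Compound 1 `COc1cc2ncnc(Nc3cccc(Br)c3)c2cc1OCCCCC(=O)Nc1ccc(S(N)(=O)=O)cc1` gives 9750 nM. Compound 2 `COc1cc2ncnc(Nc3cccc(F)c3)c2cc1OCCCCC(=O)Nc1ccc(S(N)(=O)=O)cc1` gives 29900 nM, the highest number of the three and so the weakest inhibitor among them. Compound 3 `COc1ccc(Nc2ncnc3cc(OC)c(OCCCCC(=O)Nc4ccc(S(N)(=O)=O)cc4)cc23)cc1` gives 14700 nM. Going by the values given here, the step of a 3.1-fold higher number from compound 1 to compound 2 (0.49 log units; beyond the scatter) is the one exchange of bromo for fluoro on an aromatic carbon. The steps of a 2.0-fold lower number from compound 2 to compound 3 (0.31 log units; beyond the scatter) and a 1.5-fold higher number from compound 1 to compound 3 (0.18 log units; within the scatter) place compound 3 between the other two, with only a small gap to compound 1.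

Compound 4 `COc1cc2ncnc(Nc3ccc(F)c(Br)c3)c2cc1OCCCCC(=O)Nc1ccc(S(N)(=O)=O)cc1` has not yet been measured. It differs from compound 2 by 3-bromo-4-fluorophenyl in place of 3-fluorophenyl on a nitrogen on an aromatic ring: the fluorine remains and a bromine is added on the same ring. Among the compounds with values here, the only measured step that bears on this change is a 3.1-fold higher number from compound 1 to compound 2 (0.49 log units; beyond the scatter); read in the reverse direction, bringing a bromine back onto the ring lowered the number by that amount. Compound 4 carries both halogens, so it is expected to land near compound 1, which gives 9750 nM. The estimated step is a 3.3-fold lower number from compound 2 to compound 4 (0.52 log units; beyond the scatter). Compound 4 is therefore expected to give about 9000 nM in this assay, most likely between 3500 nM and 24000 nM.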

Compound 4, half-maximal inhibitory concentration: 8020 nM
Beside the measured number, compound 4's estimate is 1.1-fold (0.05 log units) above it; low and high end bracket the measured number.
By their numbers in this assay, from the lowest: compounds 4, 1 and 3 (each within the scatter of the next); then compound 2.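

In this assay, exchanging 3-fluorophenyl for 3-bromo-4-fluorophenyl on the nitrogen gives a 3.7-fold lower number from compound 2 to compound 4 (0.57 log units; beyond the scatter), a step beyond the scatter, so a second compound with bromine on this ring also has a lower number than compound 2. Fluoro in place of hydrogen on the ring of compound 1 gives a 1.2-fold lower number from compound 1 to compound 4 (0.08 log units; within the scatter), which lies within the scatter, so this position on the bromo-substituted ring accepts the added fluorine with no readable change in this assay. Exchanging 4-methoxyphenyl for 3-bromo-4-fluorophenyl gives a 1.8-fold lower number from compound 3 to compound 4 (0.26 log units; within the scatter), also within the scatter, so these two rings cannot be told apart here, although they share no substituent.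

On these data alone, it remains open whether a chloro group, a nitrile or an ethynyl group on this ring would match bromo, and whether a shorter or longer chain between the core and the sulfonamide-bearing ring would shift these numbers. Nothing available here gives a reason for any of these steps.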